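Swapping the thiophene for a thiazole in compound 2

The compounds below may be only part of what the source reports. "The series", "measured", "known", "first", "only" and "open" are said of these compounds alone.

Measured in a functional assay on MT2 cells (Homo sapiens) for cytotoxicity, read by MTT assay; on this read-out higher numbers stand for lower toxicity in this test and lower numbers for higher toxicity in this test:
compound 1 `N#Cc1ccc(Nc2nccs2)cc1OCc1cccs1` gives 4100 nM
compound 2 `N#Cc1ccc(Nc2nccs2)cc1OCc1ccsc1` gives 1100 nM

Compound 2 stands lowest of the two at 1100 nM. Compound 3 `N#Cc1ccc(Nc2nccs2)cc1OCc1nccs1` carries 1,3-thiazol-2-yl in place of thiophen-3-yl on a saturated chain carbon bound to an oxygen on an aromatic ring. Going by the values given here, the one measured step at this place is a 3.7-fold lower number from compound 1 to compound 2 (0.57 log units; beyond the scatter), a modest change from thiophen-2-yl to thiophen-3-yl. No 1,3-thiazol-2-yl compound has been measured, so a step of similar size is expected in this assay, tentatively towards a higher number, as compound 2 is the lower of the pair. The step expected is a 2.3-fold higher number from compound 2 to compound 3 (0.36 log units; beyond the scatter). For compound 3 the estimate is 2500 nM, with an expected range from 900 nM to 7000 nM.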

Compound 3, half-maximal cytotoxic concentration: 20000 nM
Compound 3: middle estimate off by 8.0-fold (0.90 log units), on the low side, outside the stated range (above it).
By their numbers in this assay, from the lowest: compound 2; then compound 1; then compound 3.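

In this assay the entry of 1,3-thiazol-2-yl brings an 18-fold higher number from compound 2 to compound 3 (1.26 log units; beyond the scatter) and a 4.9-fold higher number from compound 1 to compound 3 (0.69 log units; beyond the scatter) at this saturated chain carbon bound to an oxygen on an aromatic ring. The earlier compounds shown here showed only how the two thiophene attachments differ, whereas compound 3, with 2 hetero atoms in its five-membered aromatic ring, stands above both, on the side of lower toxicity in this test. Nothing at hand accounts for this shift. Still open, as far as these compounds go, is where a plain phenyl ring or a 1,3-thiazol-5-yl group on the same carbon would fall.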